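This account rests on a few compounds, and the source may have more. Where it says the series, first, only, none or still open, it means among the compounds named here.

Measured compounds:

Compound 1, `COC(=O)[C@@]1(C)CCC=C2[C@@H]1CC[C@@H](C)[C@]2(C)Cc1c[nH]c2ccc(Br)cc12`: 15000 nM
Compound 2, `COC(=O)[C@@]1(C)CCC=C2[C@@H]1CC[C@@H](C)[C@]2(C)Cc1c[nH]c2ccc(Cl)cc12`: 16000 nM
Compound 3, `COC(=O)[C@@]1(C)CCC=C2[C@@H]1CC[C@@H](C)[C@]2(C)Cc1c(C)[nH]c2c(Br)cccc12`: 27000 nM

All three were tested in a functional assay on A549 cells (Homo sapiens) for inhibition, read by sulforhodamine B assay, with a stated time of 48 h; a higher number here means a weaker inhibitor of growth, a lower number a stronger inhibitor of growth. Compound 1 gives 15000 nM, compound 2 gives 16000 nM, and compound 3 gives 27000 nM. Compound 1 and compound 2 differ in one place, (chloro in place of bromo on an aromatic carbon); this step is a 1.1-fold higher number from compound 1 to compound 2 (0.03 log units; within the scatter). Compound 3 carries a different core, and the difference between the two cores is not broken down here.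

Compound 4, `COC(=O)[C@@]1(C)CCC=C2[C@@H]1CC[C@@H](C)[C@]2(C)Cc1c(C)[nH]c2c(Cl)cccc12`, has not been measured. It differs from compound 3 in one place, (chloro in place of bromo on an aromatic carbon). Among the measured compounds shown here, this is the same kind of change as the one from compound 1 to compound 2, though not the same, since the positions read differently: meta to a fused ring and para to a fused ring in the first pair, ortho to a fused ring and meta to a fused ring in the second.

Because the step of a 1.1-fold higher number from compound 1 to compound 2 (0.03 log units; within the scatter) stayed within the scatter, compound 4 is expected to give a number close to compound 3, the step being estimated at a 1.0-fold higher number from compound 3 to compound 4 (0.02 log units; within the scatter). The estimate for compound 4 in this assay is 28000 nM, expected to lie between 14000 nM and 56000 nM.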

Compound 4, concentration for 50% growth inhibition: 20000 nM
Beside the measured number, compound 4's estimate is 1.4-fold (0.15 log units) above it, within the range that was stated.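

In this assay, chloro in place of bromo on an aromatic carbon gives a 1.4-fold lower number from compound 3 to compound 4 (0.13 log units; within the scatter), a step too small to count as a real change in growth inhibition. Set beside the earlier step, the same swap reads alike on the two cores: the same change on two cores in this assay, a 1.1-fold higher number (0.03 log units; within the scatter) from compound 1 to compound 2 and a 1.4-fold lower number (0.13 log units; within the scatter) from compound 3 to compound 4, 1.4-fold (0.16 log units) apart, within the scatter of two such steps. This shows only that exchanging these two halogens made no clear difference in either pair; it does not show that the swap would be as quiet on a third core, and since the halogen also sits at a different place in each pair, the effect of the core cannot be separated from the effect of position.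

All the compounds shown carry bromo or chloro on the aromatic ring, so it remains open how a fluoro group, a methoxy group or an amine at these places would read. The methyl ester is also the same throughout, which leaves open what a carboxylic acid or an amide there would do.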